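Aminopyrazole-fused cores against Chk2: from methyl to pyridinyl

The compounds below may be only part of what the source reports. "The series", "measured", "known", "first", "only" and "open" are said of these compounds alone.

Measured so far:
Compound 1 `Cc1cc2c(c(N)nn2C)c(=O)[nH]1`: 3%
Compound 2 `COCCNc1nc(C)cc2c1c(N)nn2C`: -2%
Compound 3 `Cc1cc2nn(-c3ccccc3)c(N)c2c(=O)[nH]1`: -4%

Of the compounds shown here, three have been tested in an assay on isolated protein for inhibition of serine/threonine-protein kinase Chk2 (Homo sapiens), read by mobility shift assay, tested at 30 uM; on this read-out higher numbers stand for more inhibition at the one concentration tested (going by the name of the read-out) and lower numbers for less inhibition. Compound 1 `Cc1cc2c(c(N)nn2C)c(=O)[nH]1` gives 3% in this assay. Compound 2 `COCCNc1nc(C)cc2c1c(N)nn2C` gives -2%. Compound 3 `Cc1cc2nn(-c3ccccc3)c(N)c2c(=O)[nH]1` gives -4%. These three numbers sit within the usual scatter of one another, so none of the compounds can be said to give a higher or lower number than the others; all three numbers are level at the single concentration tested.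

Compound 4 `Nc1c2c(=O)[nH]c(-c3ccccn3)cc2nn1-c1ccccc1` has not yet been measured. It differs from compound 3 in one place: pyridin-2-yl in place of methyl on an aromatic carbon. The shared core, the amino group and the phenyl ring on the nitrogen of the five-membered ring stay the same.

Within the data shown here, no pair of measured compounds differs in a single place, so there is no step on which to rest an expectation of size or direction. Compound 3, which carries the methyl group, gives -4% in this assay, and nothing in the present set shows that a larger ring at that position would change this number. The expected step from compound 3 to compound 4 is therefore a number 9 percentage points higher from compound 3 to compound 4 (within the scatter), a change not beyond the scatter. Compound 4 is expected to give about 5%, within a range of -10% to 25%.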

Compound 4, a percentage reported as inhibition, at one concentration (the size of the read-out at that concentration, not a potency): 3%
Estimate against measurement, compound 4: 2 percentage points above, within the range that was stated.
By their numbers in this assay, from the lowest: compounds 3, 2, 1 and 4 (each within the scatter of the next).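

In this assay, this position now has its first readable step, the swap of methyl for pyridin-2-yl: a number 7 percentage points higher from compound 3 to compound 4 (within the scatter). The aromatic carbon next to the ring nitrogen can therefore carry a whole six-membered aromatic ring with a hetero atom, not just a methyl group, and the number stays level with that of compound 3 at the one concentration tested, so adding this ring and its hydrogen-bond acceptor has shown no measurable gain or loss of inhibition. Nothing measured here gives a reason for this result.

The compounds shown leave open whether any other group at this position, such as an amine, a carboxylic acid or a longer chain, would move the number in this assay beyond the usual scatter. They also leave open whether pyridin-2-yl would read the same with a methyl group in place of the phenyl ring on the nitrogen of the five-membered ring, as in compound 1, since that pairing is not among the compounds shown.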